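An ester-bearing chain replaces an aryl group

This account rests on a few compounds, and the source may have more. Where it says the series, first, only, none or still open, it means among the compounds named here.

In an ADME assay on Huh-7 cells (Homo sapiens) for cytotoxicity, read by MTT assay, with a stated time of 72 h (a lower number here means that less compound is tolerated, a higher number that more compound is tolerated), the three measured compounds give:
compound 1 `Cc1cc(=O)oc2cc(OCc3cn(-c4ccc(F)c(Cl)c4)nn3)ccc12`: > 100 ug/mL
compound 2 `Cc1cc(=O)oc2cc(OCc3cn(-c4ccccc4[N+](=O)[O-])nn3)ccc12`: > 100 ug/mL
compound 3 `Cc1cc(C)cc(-n2cc(COc3ccc4c(C)cc(=O)oc4c3)nn2)c1`: > 100 ug/mL

For compound 3 this is a limit of the measurement, not a number. Compound 1 and compound 2 likewise end at a limit, as summed up in the limit of > 100 ug/mL in this assay, at which 3 of the 3 values shown sit. The steps between them, a step that the two limits leave unreadable from compound 1 to compound 2, a step that the two limits leave unreadable from compound 1 to compound 3 and a step that the two limits leave unreadable from compound 2 to compound 3, therefore carry no readable size and show no direction.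

Compound 4 `COC(=O)Cn1cc(COc2ccc3c(C)cc(=O)oc3c2)nn1` differs from compound 3 in one place: (methoxycarbonyl)methyl in place of 3,5-dimethylphenyl on an aromatic nitrogen. Going by the values given here, no measured step covers such a change, and nothing among the three compounds points to a drop in what is tolerated. Compound 4 is expected at 150 ug/mL, between 60 ug/mL and 400 ug/mL. The estimated step is a step that the limit leaves unreadable from compound 3 to compound 4, most likely again ending at a limit.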

Compound 4, half-maximal cytotoxic concentration: > 100 ug/mL
Compound 4: a limit, no number; the forecaster's own chance of this, stated with the estimate: 80%; the middle value is on the limit's open side.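

Going by these compounds alone, compound 4 ends at a limit, as do compound 1, compound 2 and compound 3, so no step among them can be read. The compounds shown leave open where any of them would reach its half-maximal cytotoxic concentration in this assay and whether the groups on the aromatic nitrogen make any difference.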